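The source may report more compounds than this note shows. Statements on the series, on what has been measured and on what is new or still open speak of the compounds shown alone.

Measured compounds:
compound 1, `CCCSc1nc(Cl)c2c(n1)N(Cc1ccccc1)C(C(=O)N1CCN(C(=O)OC(C)(C)C)CC1)N2` — 31200 nM
compound 2, `CCCSc1nc(Cl)c2c(n1)N(Cc1cccs1)C(C(=O)N1CCN(C)CC1)N2` — 39400 nM

Two compounds have been run in a functional assay on TE-1 cells (Homo sapiens) for antiproliferative activity, read by MTT assay, with a stated time of 72 h; on this read-out lower numbers stand for stronger inhibition and higher numbers for weaker inhibition. Compound 1 gives 31200 nM there, and compound 2 gives 39400 nM. These two numbers sit within the usual scatter of each other, so neither compound is set apart from the other on the present figures; compound 2 simply carries one of two closely matched, weak readings.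

Compound 3, `CCCSc1nc(Cl)c2c(n1)N(CC1CCCCC1)C(C(=O)N1CCN(C)CC1)N2`, has not yet been tested. It differs from compound 2 in one place: cyclohexyl in place of thiophen-2-yl on a saturated chain carbon bound to a nitrogen on an aromatic ring in a ring, so a saturated carbon ring takes the place of the aromatic one. Among the compounds with values here, no step between measured compounds covers this exchange, and the two available values give no guide on how this part of the molecule is read by this assay. The expectation is therefore that the step of a 1.1-fold lower number from compound 2 to compound 3 (0.05 log units; within the scatter) stays within the scatter, with no direction preferred. On that basis compound 3 is estimated to give about 35000 nM in this assay, with a plausible range from 12000 nM to 100000 nM.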

Compound 3, half-maximal inhibitory concentration: > 64000 nM
Compound 3: a limit, no number (the forecaster's own chance of this, stated with the estimate: 25%); middle value at least 1.8-fold (0.26 log units) from the limit.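

In this assay compound 3 gives > 64000 nM, which is a limit of the assay and not a number. Cyclohexyl in place of thiophen-2-yl, on a saturated chain carbon bound to a nitrogen on an aromatic ring in a ring, is the first change in a single place that can be read in this series, and it gives an at least 1.6-fold higher number from compound 2 to compound 3 (0.21 log units; that floor lies within the scatter), so this saturated carbon ring offers no sign of a stronger reading than the aromatic thiophen-2-yl at this place. How large the step really is cannot be told, because only its floor is known: the limit of > 64000 nM in this assay, at which 1 of the 3 values shown sits.

As far as these compounds go, whether a ring carrying an amine or a carboxylic acid, or a longer chain between the ring and the nitrogen, would bring the number down at this place remains open. Compound 1 differs from compound 2 in more than one place, so what its own groups contribute to the reading cannot be separated from these two compounds.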